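The source may report more compounds than this note shows. Statements on the series, on what has been measured and on what is new or still open speak of the compounds shown alone.

Working notes on the series in a functional assay on Ehrlich cells (Mus musculus) for antiproliferative activity, read by trypan blue exclusion, with a stated time of 2 h, tested at 10 ug/mL; a higher number here means a stronger effect of the compound at the concentration tested, a lower number a weaker effect. Compound 1, `N#CC1=C(N)N(c2ccc(S(N)(=O)=O)cc2)C2=C(C(=O)CCC2)C1c1c(O)ccc2ccccc12`, gives 0% in this assay. Compound 2, `COc1ccc(C2C(C#N)=C(N)N(c3ccc(S(N)(=O)=O)cc3)C3=C2C(=O)CCC3)c2ccccc12`, gives 10% in this assay. Among the compounds with values here, compound 2 therefore stands at the higher of the two numbers so far, but the one step that separates it from compound 1, a number 10 percentage points higher from compound 1 to compound 2 (within the scatter), lies within the scatter, so the two values are not told apart.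

Compound 3, `Cc1ccoc1C1C(C#N)=C(N)N(c2ccc(S(N)(=O)=O)cc2)C2=C1C(=O)CCC2`, has not been measured. It differs from compound 2 as follows: 3-methylfuran-2-yl in place of 4-methoxynaphthalen-1-yl on a saturated ring carbon. Within the data shown here, the only measured step, a number 10 percentage points higher from compound 1 to compound 2 (within the scatter), also changes the group on that saturated ring carbon, exchanging one naphthyl group for another, and it does not move the read-out beyond the scatter. Among the measured compounds shown here, no measured step exchanges a naphthyl group for a furan ring, so the data give no direct guide to this change; both measured values sit near the bottom of the scale.

On that basis the step of a number 5 percentage points lower from compound 2 to compound 3 (within the scatter) is expected to stay within the scatter. Compound 3 is estimated at 5% in this assay, with a likely range from 0% to 25%.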

Compound 3, a percentage reported as activity, at one concentration (the size of the read-out at that concentration, not a potency): 2%
Compound 3: the middle estimate sits 3 percentage points above what was measured; the range from low to high includes it.
By their numbers in this assay, from the lowest: compounds 1, 3 and 2 (each within the scatter of the next).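

In this assay, within the data shown here, the saturated ring carbon of the shared core now carries 3-methylfuran-2-yl, 6 heavy atoms in one five-membered aromatic ring with 1 hetero atom, where the earlier compounds carry a naphthyl group, and the exchange for 4-methoxynaphthalen-1-yl, 12 heavy atoms in 2 six-membered aromatic rings of carbon only, gives a number 8 percentage points lower from compound 2 to compound 3 (within the scatter) while the exchange for 2-hydroxynaphthalen-1-yl gives a number 2 percentage points higher from compound 1 to compound 3 (within the scatter) in the same read-out. Among these compounds, the earlier step compared only two naphthyl groups, whereas these steps show that, among compounds 1, 2 and 3, neither the change of ring type nor the count of heavy atoms on this carbon separates the values, and all three remain undistinguished. No measurement at hand offers an explanation for this result.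

From the compounds shown here alone, whether an amine, a carboxylic acid or a longer chain on this saturated ring carbon would give a read-out beyond the scatter of these three values stays open. Also open, going by these compounds, is whether a group other than the cyano group, or other than the 4-sulfamoylphenyl group on its ring atom, would move the read-out in this assay at all.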